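Compound 3: dropping the semicarbazide link from compound 2

The source may report more compounds than this note shows. Statements on the series, on what has been measured and on what is new or still open speak of the compounds shown alone.

Values in a functional assay on NCI-H460 cells (Homo sapiens) for inhibition, read by MTT assay, with a stated time of 72 h; a higher number here means a weaker inhibitor, a lower number a stronger inhibitor:
Compound 1 `COc1cc(NC(C)CCCNC(=O)NNC(=O)Nc2cccc(Cl)c2)c2ncccc2c1`: 32000 nM
Compound 2 `COc1cc(NC(C)CCCNC(=O)NNC(=O)Nc2ccc(O)cc2)c2ncccc2c1`: > 100000 nM
Compound 3 `COc1cc(NC(C)CCCNC(=O)Nc2ccc(O)cc2)c2ncccc2c1`: not yet measured

Compound 2 gives only a limit of the assay, > 100000 nM.

Compound 3 differs from compound 2 by one change: 4-hydroxyphenyl in place of ((4-hydroxyphenyl)carbamoyl)amino on an amide-type nitrogen. 4-hydroxyphenyl stands in place of ((4-hydroxyphenyl)carbamoyl)amino on an amide-type nitrogen, and the shared core is kept.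

For the measured compounds named here, only one measured step exists, an at least 3.1-fold higher number from compound 1 to compound 2 (0.49 log units; beyond the scatter). It exchanges the terminal aryl group and leaves the link intact, so it bears on this change only indirectly. Going by the values given here, the sole numerical anchor remains compound 1 at 32000 nM. A modest move toward a lower number in this assay is therefore expected, with wide uncertainty, and a second limit remains possible.

The expected change is an at least 2.5-fold lower number from compound 2 to compound 3 (0.39 log units; beyond the scatter).

For compound 3 the estimated value is 40000 nM, with an expected range of 10000 nM to 100000 nM.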

Compound 3, half-maximal inhibitory concentration: 34000 nM
Estimate against measurement, compound 3: 1.2-fold (0.07 log units) above, within the range that was stated.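

In this assay, removing the semicarbazide link while keeping the 4-hydroxyphenyl end gives an at least 2.9-fold lower number from compound 2 to compound 3 (0.46 log units; beyond the scatter), so the link itself affects the readout and the terminal aryl group is not the only point of control. With the link gone, the 4-hydroxyphenyl end comes level with the 3-chlorophenyl semicarbazide, at a 1.1-fold higher number from compound 1 to compound 3 (0.03 log units; within the scatter). The first step has only a lower bound on its size, as compound 2 stands at a limit of the assay: the limit of > 100000 nM in this assay, at which 1 of the 3 values shown sits.

The compounds shown leave open whether 3-chlorophenyl placed directly on the amide-type nitrogen would also change the number in this assay. Also open, as far as these compounds go, is whether an amine or a carboxylic acid on the terminal ring, or a longer chain in place of the link, would move the value beyond the scatter.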